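The source may report more compounds than this note shows. Statements on the series, on what has been measured and on what is new or still open speak of the compounds shown alone.

In an assay on HEK293 cells for activation of Kir3.1/Kir3.2 (Homo sapiens), read by thallium flux (on this read-out higher numbers stand for an effect only at larger amounts of compound and lower numbers for an effect already at smaller amounts), three compounds have been measured:

compound 1, `Cc1cc(NC(=O)Cn2nnc(-c3ccccc3)n2)n(C2CCCC2)n1`, gives 163 nM
compound 2, `Cc1cc(NC(=O)Cn2nnc(-c3ccccc3)n2)n(CC2CCCCC2)n1`, gives 176 nM
compound 3, `Cc1cc(NC(=O)Cn2nnc(-c3ccccc3F)n2)n(C2CCCCC2)n1`, gives 187 nM

Compound 3 holds the highest of the three numbers in this assay, but its nearest neighbour compound 2 and its furthest neighbour compound 1 both lie within the scatter of it, so the three compounds are not told apart. Among the measured compounds shown here, the one step that can be computed, a 1.1-fold higher number from compound 1 to compound 2 (0.03 log units; within the scatter), concerns the group on the aromatic nitrogen and lies within the scatter as well.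

Compound 4, `Cc1cc(NC(=O)Cn2nnc(-c3cccc(C#N)c3)n2)n(C2CCCCC2)n1`, differs from compound 3 in another place: 3-cyanophenyl in place of 2-fluorophenyl on an aromatic carbon. For the measured compounds named here, no measured pair touches the group on this aromatic carbon, so the data give no step that bears directly on the change. Going by the values given here, the only step at hand is small and at a different position. Compound 4 is therefore expected to stay close to compound 3, with a step of a 1.0-fold higher number from compound 3 to compound 4 (0.01 log units; within the scatter) that does not go beyond the scatter, and its estimated value in this assay is 190 nM, within a range from 80 nM to 450 nM.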

Compound 4, half-maximal effective concentration: 183 nM
Beside the measured number, compound 4's estimate is 1.0-fold (0.02 log units) above it, within the range that was stated.
By their numbers in this assay, from the lowest: compounds 1, 2, 4 and 3 (each within the scatter of the next).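

In this assay, among the compounds shown here, the step at this position, a 1.0-fold lower number from compound 3 to compound 4 (0.01 log units; within the scatter), gives the first direct reading on the group carried by the aromatic carbon of the five-membered ring, and it does not tell 2-fluorophenyl and 3-cyanophenyl apart. The entering group brings a triple bond and a hydrogen-bond acceptor that the leaving group lacks, and this difference in make-up leaves no readable mark on the number. Since the swap alters both the substituent on the phenyl ring and its place there, the step cannot separate those two differences, and nothing at hand explains the result.

The compounds shown leave open whether a carboxylic acid or an amine on the phenyl ring would also stay within the scatter of compound 3. They also leave open what a plain alkyl chain in place of the phenyl ring would give.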